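A few compounds are considered here, and "the series" means these few. Any claim that something is new, unique, unknown or untested is made for them only; others in the source may bear on it.

Measured so far:
compound 1 `Cc1[nH]cnc1CN1CCN(c2ccccc2)C1=O` — 26.9 nM
compound 2 `Cc1[nH]cnc1CN1CCN(c2cccc(C(F)(F)F)c2)C1=O` — 68.5 nM

In a functional assay (Cavia porcellus) for antagonist activity at Serotonin 3 (5-HT3) receptor (Homo sapiens) (on this read-out higher numbers stand for weaker inhibition and lower numbers for stronger inhibition), compound 1 stands as the lower of the two numbers. For the measured compounds named here, its only neighbour is compound 2, and the step of a 2.5-fold higher number from compound 1 to compound 2 (0.41 log units; beyond the scatter) puts trifluoromethyl in place of hydrogen on the aromatic carbon of the phenyl ring. Compound 3 `O=C1N(Cc2c[nH]cn2)CCN1c1ccccc1` has not yet been measured in this assay. It differs from compound 1 by hydrogen in place of methyl on an aromatic carbon, a change at the five-membered ring rather than at the phenyl ring. Going by the values given here, the single measured step, from compound 1 to compound 2, therefore tells nothing about this place; no step in the set bears on it. With no guidance, compound 3 is expected to stay close to compound 1 in this assay, with the estimated step of a 1.5-fold higher number from compound 1 to compound 3 (0.17 log units; within the scatter) possibly a slight weakening but not clearly beyond the scatter. Compound 3 is estimated at 40 nM, in a range of 15 nM to 110 nM.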

Compound 3, antagonist equilibrium constant: 45.4 nM
Beside the measured number, compound 3's estimate is 1.1-fold (0.05 log units) below it; low and high end bracket the measured number.
By their numbers in this assay, from the lowest: compounds 1, 3 and 2 (each within the scatter of the next, the first and the last beyond it).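

For the compounds shown here, with hydrogen in place of methyl on this aromatic carbon of the five-membered ring, this assay gives a 1.7-fold higher number from compound 1 to compound 3 (0.23 log units; within the scatter), the first reading at a place the phenyl-ring step could not reach. On this single pair, 5-methyl-1H-imidazol-4-yl and 1H-imidazol-4-yl cannot be told apart, so the methyl is not shown to matter to the read-out. No available evidence speaks to this result.

The compounds shown leave open whether a group other than methyl or hydrogen at this carbon, such as an ethyl, a hydroxymethyl or an amine, would stay just as close to compound 1. They also leave open whether trifluoromethyl on the phenyl ring would give a similar step on compound 3 as it does on compound 1.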